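Triazole substituent swap on a bromoquinoline scaffold

The source may report more compounds than this note shows. Statements on the series, on what has been measured and on what is new or still open speak of the compounds shown alone.

Compound 2 `COc1nc2ccc(Br)cc2cc1C(c1ccccc1)n1cc(-c2ccccc2C(F)(F)F)nn1` gives the higher of two numbers in an ADME assay on HeLa cells (Homo sapiens) for cytotoxicity, read by sulforhodamine B assay, with a stated time of 48 h, tested at 10 uM (on this read-out lower numbers stand for less inhibition and higher numbers for more inhibition at the one concentration tested (going by the name of the read-out)), where compound 2 reaches -1.3%; compound 1 `CCCCCc1cn(C(c2ccccc2)c2cc3cc(Br)ccc3nc2OC)nn1` lies nearby at -9.81%, the step of a number 8.5 percentage points higher from compound 1 to compound 2 (within the scatter). Compound 3 `CCOC(=O)c1cn(C(c2ccccc2)c2cc3cc(Br)ccc3nc2OC)nn1` differs from compound 2 by ethoxycarbonyl in place of 2-(trifluoromethyl)phenyl on an aromatic carbon. Going by the values given here, only one step bears on this change, and it stayed within the scatter, so compound 3 is expected to show no step beyond the scatter, a number 2.7 percentage points lower from compound 2 to compound 3 (within the scatter). Compound 3 is therefore estimated at -4%, with a range from -16% to 10%.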

Compound 3, a percentage reported as inhibition, at one concentration (the size of the read-out at that concentration, not a potency): -3.67%
Compound 3: middle estimate off by 0.3 percentage points, on the low side, and the stated range covers the measured number.
By their numbers in this assay, from the lowest: compounds 1, 3 and 2 (each within the scatter of the next).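

On the aromatic carbon of the five-membered aromatic ring, ethoxycarbonyl, which has no ring and brings 2 hydrogen-bond acceptors, leaves this assay within the scatter of both earlier groups, 2-(trifluoromethyl)phenyl (a number 2.4 percentage points lower from compound 2 to compound 3 (within the scatter)) and pentyl (a number 6.1 percentage points higher from compound 1 to compound 3 (within the scatter)). Across these three groups, this position has therefore shown no step beyond the scatter. Nothing available explains this result. On these data alone, whether an amine or a carboxylic acid at this position would produce a step beyond the scatter remains open.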